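A few compounds are considered here, and "the series" means these few. Any claim that something is new, unique, unknown or untested is made for them only; others in the source may bear on it.

In a functional assay on HCT-116 cells (Homo sapiens) for antiproliferative activity, read by MTT assay, with a stated time of 72 h (a higher number here means a weaker inhibitor, a lower number a stronger inhibitor), the measured compounds are:

compound 1 `COc1ccc(/C=C2/CN(C)/C(=N/c3ccc(C)cc3)S2)cc1` gives 11100 nM
compound 2 `COc1ccc(/C=C2\S/C(=N\c3ccccc3)N(C)C2=O)cc1` gives > 100000 nM, which is a limit of the assay and not a number
compound 3 `COc1ccc(/C=C2/CN(C)/C(=N/c3ccc(C(C)(C)C)cc3)S2)cc1` gives 25900 nM

Compound 2 thus stands at the limit of > 100000 nM in this assay, at which 1 of the 3 values shown sits, the weakest reading that this assay reports. Compound 4 `COc1ccc(/C=C2\S/C(=N\c3ccc(Br)cc3)N(C)C2=O)cc1` differs from compound 2 by bromo in place of hydrogen on an aromatic carbon. Among the measured compounds shown here, no measured step covers this change; the only measured step, a 2.3-fold higher number from compound 1 to compound 3 (0.37 log units; beyond the scatter), concerns a different group on a different core. On a core that gives only a limit for compound 2, compound 4 is expected to remain weak, with the step of an at least 1.2-fold lower number from compound 2 to compound 4 (0.09 log units; that floor lies within the scatter) uncertain in direction. Compound 4 is therefore estimated at 80000 nM, within 20000 nM to 300000 nM.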

Compound 4, half-maximal inhibitory concentration: 17000 nM
Beside the measured number, compound 4's estimate is 4.7-fold (0.67 log units) above it, outside the stated range (below it).
By their numbers in this assay, from the lowest: compounds 1, 4 and 3 (each within the scatter of the next, the first and the last beyond it). At a limit, above all of these: compound 2.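

In this assay the bromo group, on an aromatic carbon para to a large group, gives a measurable reading on a core that otherwise stood at a limit, with an at least 5.8-fold lower number from compound 2 to compound 4 (0.76 log units; beyond the scatter) on going from phenyl to 4-bromophenyl. Compound 2 gives > 100000 nM, which is a limit of the assay and not a number, so this step has only a floor. The earlier step concerned a different group on a different core and could not show this.

The compounds shown leave open whether chloro, an amine or a carboxylic acid at this place would also leave the limit. As far as these compounds go, whether bromo would change the reading on the core of compound 1 also stays open.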